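The compounds below may be only part of what the source reports. "The series", "measured", "known", "first", "only" and "open" are said of these compounds alone.

Measured so far in a functional assay on the whole organism (blood, strain Charles Foster/Wistar albino) with Rattus norvegicus as the target, with a stated time of 30 min, at a dose of 100 mg/kg by the oral route; a lower number here means less inhibition, a higher number more inhibition at the dose given (going by the name of the read-out):
compound 1 `COc1ccc(-c2cc(-c3ccccc3)no2)c(OCCCN2CCCCC2)c1`: 20.8%
compound 2 `COc1ccc(-c2cc(-c3ccccc3)no2)c(OCC(O)CN2CCCCC2)c1`: 17%

For the measured compounds named here, compound 2 carries the smaller of the two numbers, with compound 1 as its only neighbour; the step of a number 3.8 percentage points lower from compound 1 to compound 2 (within the scatter) is within the scatter, so the two cannot be told apart on these data. Compound 3 `CCCCN(C)CCCOc1cc(OC)ccc1-c1cc(-c2ccccc2)no1` is not yet measured. It differs from compound 2 in one place: 2-(butyl(methyl)amino)ethyl in place of 1-hydroxy-2-(piperidin-1-yl)ethyl on a saturated chain carbon bound to an oxygen on an aromatic ring. Going by the values given here, only one measured step bears on this change, a number 3.8 percentage points lower from compound 1 to compound 2 (within the scatter), which covers the hydroxy part of the difference in the reverse direction and is within the scatter. Among the compounds with values here, for the exchange of the piperidine-bearing chain for the butyl(methyl)amino-bearing chain no measured pair exists. The step is therefore expected to be small, a number 2 percentage points higher from compound 2 to compound 3 (within the scatter), with no direction beyond the scatter. Compound 3 is estimated at 19%, in the range 8% to 30%.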

Compound 3, a percentage reported as inhibition, in the whole organism at one dose (the size of the read-out at that dose, not a potency): 15%
For compound 3 the middle estimate is 4 percentage points above the measured one, within the range that was stated.
By their numbers in this assay, from the lowest: compounds 3, 2 and 1 (each within the scatter of the next).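

In this assay, the exchange of piperidin-1-yl for butyl(methyl)amino on the chain gives a number 5.8 percentage points lower from compound 1 to compound 3 (within the scatter), so on these data the six-membered non-aromatic ring at the chain end can be replaced by an open-chain amine with no difference that can be read. The larger exchange, 2-hydroxy-3-(piperidin-1-yl)propyl to 3-(butyl(methyl)amino)propyl, which removes both the hydroxy and the ring, gives a number 2 percentage points lower from compound 2 to compound 3 (within the scatter) and likewise cannot be told apart from no difference. Nothing available explains the similar numbers across these side chains.

As far as these compounds go, whether a morpholine or a primary amine at the chain end would give a number beyond the scatter remains open. So does the effect of a longer chain between the aromatic oxygen and the amine.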